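The compounds below may be only part of what the source reports. "The series", "measured", "known", "first", "only" and "open" are said of these compounds alone.

Within the data shown here, compound 2 `CC(C#Cc1cccc(C(=O)NCc2ccccc2C(F)(F)F)c1)N(O)C(N)=O` gives the higher of the two numbers so far in an assay for inhibition of Polyunsaturated fatty acid 5-lipoxygenase (Homo sapiens), read by HPLC, with stated times of 15 min and 10 min (a lower number here means a stronger inhibitor, a higher number a weaker inhibitor), namely 700 nM. Compound 1 `C[C@H](C#Cc1cccc(C(=O)NCc2ccccc2C(F)(F)F)c1)N(O)C(N)=O` gives 600 nM. Among the measured compounds shown here, the only measured step, a 1.2-fold higher number from compound 1 to compound 2 (0.07 log units; within the scatter), rests on the fact that one of compounds 1 and 2 is drawn with a defined configuration and the other without, at the place where they differ and touches no chain length. Compound 3 `CCCC(C#Cc1cccc(C(=O)NCc2ccccc2C(F)(F)F)c1)N(O)C(N)=O` carries ethyl in place of hydrogen on a saturated chain carbon, two bonds along the chain from an amide-type nitrogen and a triple-bonded carbon. For the measured compounds named here, since no measured step changes a carbon chain, no step bears on this change, and no shift beyond the usual scatter is expected in this assay. Compound 3 is therefore estimated at 700 nM, with a likely range from 250 nM to 2000 nM. The step expected is no change at the digits printed from compound 2 to compound 3 (within the scatter).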

Compound 3, half-maximal inhibitory concentration: 300 nM
Compound 3: the middle estimate sits 2.3-fold (0.37 log units) above what was measured, and the stated range covers the measured number.
By their numbers in this assay, from the lowest: compounds 3, 1 and 2 (each within the scatter of the next, the first and the last beyond it).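

Lengthening the chain on this saturated chain carbon from methyl to propyl gives a 2.3-fold lower number from compound 2 to compound 3 (0.37 log units; beyond the scatter), so in this assay this position tolerates a longer chain with no loss of inhibition. Among these compounds, measured against the compound drawn with a defined configuration, the change reads a 2.0-fold lower number from compound 1 to compound 3 (0.30 log units; within the scatter), so the shift is modest and passes the scatter on only one of the two readings. Nothing given here accounts for this shift. Still open, from the compounds shown here alone, is how a butyl chain or a phenyl group on this carbon would read, and how the two configurations of the propyl compound compare.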